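The source may report more compounds than this note shows. Statements on the series, on what has been measured and on what is new or still open speak of the compounds shown alone.

Compound 1 `C=C(c1ccccc1)c1cc(OC)c(OC)c(OC)c1-c1ccccc1`: 36000 nM
Compound 2 `C=C(c1ccc(C)cc1)c1cc(OC)c(OC)c(OC)c1-c1ccccc1`: 28000 nM
Compound 3 `C=C(c1ccc(Cl)cc1)c1cc(OC)c(OC)c(OC)c1-c1ccccc1`: 29000 nM

These three values all come from a functional assay on DU-145 cells (Homo sapiens) for cytotoxicity, read by MTT assay, with a stated time of 48 h; on this read-out lower numbers stand for stronger inhibition and higher numbers for weaker inhibition. Compound 3 cannot be separated from the other two, as both of its steps lie within the scatter: a 1.2-fold lower number from compound 1 to compound 3 (0.09 log units; within the scatter) and a 1.0-fold higher number from compound 2 to compound 3 (0.02 log units; within the scatter).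

Compound 4 `C=C(c1ccc(C(F)(F)F)cc1)c1cc(OC)c(OC)c(OC)c1-c1ccccc1` has trifluoromethyl in place of chloro on an aromatic carbon. Going by the values given here, no measured compound yet carries trifluoromethyl, so the evidence is indirect. The closest guides are the other changes at this same place. Putting chloro in place of hydrogen gave a 1.2-fold lower number from compound 1 to compound 3 (0.09 log units; within the scatter), methyl in place of hydrogen gave a 1.3-fold lower number from compound 1 to compound 2 (0.11 log units; within the scatter), and chloro in place of methyl gave a 1.0-fold higher number from compound 2 to compound 3 (0.02 log units; within the scatter). All three steps are small, so no step beyond the scatter is expected here, in either direction. The expected change is a 1.0-fold higher number from compound 3 to compound 4 (0.01 log units; within the scatter). For compound 4 the estimated value is 30000 nM, with an expected range from 16000 nM to 55000 nM.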

Compound 4, half-maximal inhibitory concentration: 31000 nM
Estimate against measurement, compound 4: 1.0-fold (0.01 log units) below; low and high end bracket the measured number.
By their numbers in this assay, from the lowest: compounds 2, 3, 4 and 1 (each within the scatter of the next).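

In this assay trifluoromethyl at this place on the ring still gives no readable change: against chloro it gives a 1.1-fold higher number from compound 3 to compound 4 (0.03 log units; within the scatter) while against methyl it gives a 1.1-fold higher number from compound 2 to compound 4 (0.04 log units; within the scatter) and against hydrogen it gives a 1.2-fold lower number from compound 1 to compound 4 (0.06 log units; within the scatter) so this group cannot be separated from any of the other three. Trifluoromethyl brings in more heavy atoms than the chloro it replaces, yet that larger swap leaves the number as unresolved as the earlier, smaller ones did. Nothing measured here accounts for why these four compounds read alike.

On these data alone, it remains open whether an amine, a carboxylic acid or a longer chain at this same place would move the number beyond the scatter. As far as these compounds go, it is also open whether changes elsewhere on the shared core would do so.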